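The source may hold more compounds than are shown below. What is called first, only, known or untested is meant among the compounds shown, and "the series" means these compounds.

Measured in a functional assay on MOLT-4 cells (Homo sapiens) for inhibition, read by MTT assay, with a stated time of 48 h; on this read-out higher numbers stand for weaker inhibition and lower numbers for stronger inhibition:
- compound 1 `CC(C)CCn1cc(/C=C/C(=O)CC(=O)C(=O)O)c2ccccc21`: 20000 nM
- compound 2 `N#Cc1ccc(Cn2cc(/C=C/C(=O)CC(=O)C(=O)O)c3ccccc32)cc1`: > 40000 nM (a limit)

Compound 2 stands at the limit of > 40000 nM in this assay, at which 1 of the 2 values shown sits, so it carries a limit and not a number. The next compound to be read is compound 3 `O=C(/C=C/c1cn(CC(=O)N2CCOCC2)c2ccccc12)CC(=O)C(=O)O`. The change is (morpholin-4-yl)carbonyl in place of 4-cyanophenyl on a saturated chain carbon bound to an aromatic nitrogen. Going by the values given here, the only measured step at this place is an at least 2.0-fold higher number from compound 1 to compound 2 (0.30 log units; that floor lies within the scatter). That step gives a floor and no full size, and it involves neither compound 3 nor its new group. No step beyond the scatter is therefore expected in this assay, and no direction is assigned. The expected change is an at least 1.1-fold lower number from compound 2 to compound 3 (0.05 log units; that floor lies within the scatter). For compound 3 the estimate is 35000 nM, with an expected range from 15000 nM to 80000 nM.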

Compound 3, half-maximal inhibitory concentration: > 40000 nM
Compound 3: a limit, no number; the forecaster's own chance of this, stated with the estimate: 50%; at least 1.1-fold (0.05 log units) between middle value and limit.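

In this assay compound 3 gives > 40000 nM, which is a limit and not a number. Two different groups on a saturated chain carbon bound to an aromatic nitrogen, 4-cyanophenyl and (morpholin-4-yl)carbonyl, now sit at the same limit: the limit of > 40000 nM in this assay, at which 2 of the 3 values shown sit.

The comparison with the isobutyl-bearing compound gives an at least 2.0-fold higher number from compound 1 to compound 3 (0.30 log units; that floor lies within the scatter), while the step joining the two limits cannot be read.

As far as these compounds go, whether a longer alkyl chain, or a chain ending in an amine or a carboxylic acid, would give a readable number at this place remains open. From the compounds shown here alone, the true values of compound 2 and compound 3 also remain open, so the two groups cannot be ranked against each other.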